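The source may hold more compounds than are shown below. What is called first, only, known or untested is meant among the compounds shown, and "the series" means these compounds.

Compound 1 `COc1cc(CCCCC(=O)/C=C/c2ccc(O)cc2)ccc1O`, compound 2 `O=C(/C=C/c1ccc(O)cc1)CCCCc1ccc(O)cc1` and compound 3 `COc1cc(CCCCC(O)CCc2ccc(O)c(OC)c2)ccc1O` were tested in an ADME assay on HT-22 cells (Mus musculus) for cytotoxicity, read by MTT assay, with a stated time of 24 h, tested at 10 uM; a higher number here means a weaker effect of the compound at the concentration tested, a lower number a stronger effect. Compound 1 gives 67%, compound 2 gives 43% and compound 3 gives 73%. Compound 2 differs from compound 1 by one change, (hydrogen in place of methoxy on an aromatic carbon), and this change made a step of a number 24 percentage points lower from compound 1 to compound 2 (beyond the scatter). Compound 4 `COc1cc(CCC(O)CCCCc2ccc(O)cc2)ccc1O` has not yet been measured in this assay; it differs from compound 3 by the same change, (hydrogen in place of methoxy on an aromatic carbon). The difference between the core of compound 1 and the core of compound 3 is not broken down here. For compound 4 a step of about a number 24 percentage points lower from compound 3 to compound 4 (beyond the scatter) is expected, because the same change gave a number 24 percentage points lower from compound 1 to compound 2 (beyond the scatter) on the other core. Compound 4 is therefore estimated at 49%, most likely between 34% and 64%.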

Compound 4, a percentage reported as activity, at one concentration (the size of the read-out at that concentration, not a potency): 75%
For compound 4 the middle estimate is 26 percentage points below the measured one; measured number outside the range, above it.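

In this assay, putting hydrogen in place of methoxy gave a number 2 percentage points higher from compound 3 to compound 4 (within the scatter) and so did not repeat the earlier step. In this series, the size of the step from this change depends on the core, and a step read on one core cannot simply be carried over to the other: the same change on two cores in this assay, a number 24 percentage points lower (beyond the scatter) from compound 1 to compound 2 and a number 2 percentage points higher (within the scatter) from compound 3 to compound 4, 26 percentage points apart, beyond the scatter of two such steps. This does not show which difference between the two cores matters or why, and two pairs say nothing about any further core.

The compounds shown leave open what an amine or a carboxylic acid in place of methoxy would do on either core. They also leave open whether a longer chain between the rings would change the step.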